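The compounds below may be only part of what the source reports. "The series", "measured", "known", "first", "only" and "open" are said of these compounds alone.

Compound 1 `CCc1cccc2cc(C(=O)O)cnc12` gives > 50 mg/kg in a functional assay on the whole organism (strain Sprague-Dawley) for inhibition, with Rattus norvegicus as the target; on this read-out lower numbers stand for an effect already at smaller amounts and higher numbers for an effect only at larger amounts of compound.
Compound 2 `COc1ccc2c(=O)c(-c3nn[nH]n3)c[nH]c2c1` gives 10 mg/kg in this assay.
Compound 3 `CCc1cccc2cc(-c3nn[nH]n3)cnc12` gives 2.5 mg/kg in this assay.

The value of compound 1 is a limit of the assay, not a measured number (the limit of > 50 mg/kg in this assay, at which 1 of the 3 values shown sits). Among the three compounds, compound 1 therefore sits at the weak end. Going by the values given here, the only measured step leads away from it: an at least 20-fold lower number from compound 1 to compound 3 (1.30 log units; beyond the scatter). Compound 4 `O=C(O)c1cnc2c(F)cccc2c1` keeps the carboxy group of compound 1 and differs only as follows: fluoro in place of ethyl on an aromatic carbon. Among the compounds with values here, no measured step touches this kind of change, so the expectation rests on compound 1 alone. Compound 4 is therefore expected to remain near the limit, with a step that the limit leaves unreadable from compound 1 to compound 4 expected to lie within the scatter. The estimate for compound 4 is 60 mg/kg, with a range from 20 mg/kg to 150 mg/kg.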

Compound 4, minimum effective dose: > 25 mg/kg
Compound 4 gave a limit, no number (the forecaster's own chance of this, stated with the estimate: 70%); the middle value lies beyond the limit too.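

Compound 4 gives > 25 mg/kg in this assay, which is a limit of the assay. Going by these compounds alone, compound 1 gives > 50 mg/kg, also a limit, so no step between them can be read. The compounds shown leave open how fluoro in place of ethyl affects the minimum effective dose.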